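A few compounds are considered here, and "the series" means these few. Any claim that something is new, unique, unknown or untested is made for them only; others in the source may bear on it.

Compound 1 `COc1cc2c(cc1OC)C(CC(=O)Nc1ccccc1)CC2` is the reference point of this short series. Within the data shown here, in a functional assay on the whole organism (strain Wistar) for inhibition, with Rattus norvegicus as the target, read by paw edema, with a stated time of 3 h, at a dose of 100 mg/kg (a higher number here means more inhibition at the dose given (going by the name of the read-out), a lower number less inhibition), compound 1 gives 36.2%, the higher of the two numbers measured so far. Among the measured compounds shown here, the only comparison in hand is with compound 2 `COc1ccccc1NC(=O)CC1CCc2cc(OC)c(OC)cc21`, which in this assay gives 21.7%; the step between them, a number 14.5 percentage points lower from compound 1 to compound 2 (beyond the scatter), came with a methoxy in place of hydrogen on an aromatic carbon.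

Compound 3 `COc1cc2c(cc1OC)C(CC(=O)Nc1ccc([N+](=O)[O-])cc1)CC2` has not yet been measured. It differs from compound 1 by nitro in place of hydrogen on an aromatic carbon. For the measured compounds named here, the single measured step bears on this only loosely: in it, too, a new group was added onto an aromatic ring of compound 1, but that group was a methoxy rather than a nitro, so it suggests a direction more than a size. That step was a modest lowering beyond the scatter, and a lowering of similar order is expected here, namely a number 8.2 percentage points lower from compound 1 to compound 3 (within the scatter). For compound 3 the estimate in this assay is therefore 28%, with an expected range from 14% to 42%, wide enough that no change beyond the scatter remains possible.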

Compound 3, a percentage reported as inhibition, in the whole organism at one dose (the size of the read-out at that dose, not a potency): 37.7%
Compound 3: the middle estimate sits 9.7 percentage points below what was measured; the measured number falls inside the stated range.
By their numbers in this assay, from the lowest: compound 2; then compounds 1 and 3 (each within the scatter of the next).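

In this assay, the step to the nitro group, on an aromatic carbon para to a large group, is a number 1.5 percentage points higher from compound 1 to compound 3 (within the scatter), so this position takes the added group with no change that can be told from the scatter. The earlier methoxy step, a number 14.5 percentage points lower from compound 1 to compound 2 (beyond the scatter), had left open whether any new group on an aromatic carbon of compound 1 would lower the number; the nitro step shows that adding a group does not by itself do so, at least for this group at this position. Nothing available accounts for the gap between the two steps.

The two steps differ in the group, and the methoxy does not stand at the position printed for the nitro, so the effect of the group and that of its place remain unseparated, and a methoxy para to a large group would be the direct test. Also open is whether an amine or a carboxylic acid at this same position would leave the number in the same range as the nitro group, and how any of these compounds would behave at a dose other than the single one reported.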